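This account rests on a few compounds, and the source may have more. Where it says the series, first, only, none or still open, it means among the compounds named here.

Working notes on the series. Three compounds have so far been run in an assay on HEK293 cells for agonist activity at transient receptor potential cation channel subfamily M member 8 (Homo sapiens), read by fluorescence and calcium flux, with a stated time of 15 min; a higher number here means that more compound is needed for the effect, a lower number that less compound is needed. Compound 1 `Cc1ccc(OCC(=O)N(Cc2cccs2)CC(C)C)cc1` gives 900 nM in this assay. Compound 2 `CCN(Cc1cccs1)C(=O)c1cc2cc(C)ccc2o1` gives 120 nM, a lower number than compound 1, the gap lying beyond the scatter. Compound 3 `CCN(Cc1cccn1C)C(=O)COc1ccc(C)cc1` gives 21300 nM, a higher number than compound 1, again beyond the scatter. For the measured compounds named here, compound 1 thus holds the second highest of the three numbers measured so far; of its two neighbours, compound 2 is the nearer and compound 3 the further.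

Compound 4 `Cc1ccc(OCC(=O)N(Cc2cccs2)c2ccccc2)cc1` has not yet been measured in this assay. It differs from compound 1 in one place: phenyl in place of isobutyl on an amide-type nitrogen. Going by the values given here, no pair of measured compounds shows this change on its own, so the size of the step is not anchored by any measured step; the gaps between compound 2 and the other two involve several changes at once and cannot be read as a step for this one. Without such an anchor, the expected step is small and its direction open, with nothing beyond the scatter claimed: the estimated change is a 1.3-fold lower number from compound 1 to compound 4 (0.11 log units; within the scatter). Compound 4 is therefore expected to give about 700 nM in this assay, with a range of 150 nM to 3000 nM, the width reflecting the absence of a measured step for this change.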

Compound 4, half-maximal effective concentration: 23 nM
Estimate against measurement, compound 4: 30-fold (1.48 log units) above; the measured number lies below the stated range.
By their numbers in this assay, from the lowest: compound 4; then compound 2; then compound 1; then compound 3.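

In this assay, for the compounds shown here, the substituent on the amide-type nitrogen proves to be a sensitive place: phenyl in place of isobutyl gives a 39-fold lower number from compound 1 to compound 4 (1.59 log units; beyond the scatter) and is the first single-place step measured here, with compound 4 at 23 nM. The change swaps a chain of 4 heavy atoms with no ring for a group of 6 heavy atoms containing one six-membered aromatic ring of carbon only, while hydrogen-bond donors, hydrogen-bond acceptors and net charge stay the same in both groups. No available measurement accounts for the size of this step.

The compounds shown do not separate the contribution of the aromatic ring from that of the larger group; cyclohexyl or benzyl on the same nitrogen would test this, and a pyridyl ring or a phenyl carrying fluorine or methoxy would show how much the ring itself tolerates change. Going by these compounds, it also remains open whether phenyl on the nitrogen gives a comparable step on the core of compound 2, where ethyl occupies that place, or on the core of compound 3.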